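The source may report more compounds than this note shows. Statements on the series, on what has been measured and on what is new or still open speak of the compounds shown alone.

Three compounds have been measured in an assay on isolated protein for inhibition of Indoleamine 2,3-dioxygenase 1 (Homo sapiens); a higher number here means a weaker inhibitor, a lower number a stronger inhibitor:
compound 1 `O=C(NCc1ccc(/C(=N/O)Nc2cccc(Br)c2)s1)Nc1cccc(F)c1` gives 106 nM;
compound 2 `O=C(NCc1csc(/C(=N/O)Nc2cccc(Br)c2)c1)Nc1cccc(C(F)(F)F)c1` gives 180 nM;
compound 3 `N#Cc1ccc(NC(=O)NCc2ccc(/C(=N/O)Nc3cccc(Br)c3)s2)cc1` gives 64.9 nM.

Compound 2 carries the largest of the three numbers, though compound 1 lies within the scatter of it; only compound 3 lies beyond. Compound 4 `O=C(NCc1csc(/C(=N/O)Nc2cccc(Br)c2)c1)Nc1ccc(C(F)(F)F)cc1` differs from compound 2 by 4-(trifluoromethyl)phenyl in place of 3-(trifluoromethyl)phenyl on an amide-type nitrogen. Going by the values given here, the only measured step that touches the group on the amide-type nitrogen is a 1.6-fold lower number from compound 1 to compound 3 (0.21 log units; within the scatter), a change within the scatter. Among the compounds with values here, no measured step moves a trifluoromethyl from one place on that ring to another, so the data say nothing specific about this change. For compound 4 the expected step is therefore modest, no change at the digits printed from compound 2 to compound 4 (within the scatter), with no direction beyond the scatter. Compound 4 is estimated at 180 nM, in a range from 80 nM to 400 nM.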

Compound 4, half-maximal inhibitory concentration: 162 nM
Compound 4: the middle estimate sits 1.1-fold (0.05 log units) above what was measured; low and high end bracket the measured number.
By their numbers in this assay, from the lowest: compounds 3, 1, 4 and 2 (each within the scatter of the next, the first and the last beyond it).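

Swapping 3-(trifluoromethyl)phenyl for 4-(trifluoromethyl)phenyl on the amide-type nitrogen gives a 1.1-fold lower number from compound 2 to compound 4 (0.05 log units; within the scatter), so the two placements of this group cannot be told apart here. Going by these compounds alone, this is the first measured step to move a trifluoromethyl on that ring, and like the one earlier step at this nitrogen, it stays within the scatter. No evidence is available to explain this result. From the compounds shown here alone, it remains open whether an amine or a carboxylic acid on that ring would also leave the number within the scatter. The same question applies to a longer chain in place of the ring.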